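This account rests on a few compounds, and the source may have more. Where it says the series, first, only, none or still open, it means among the compounds named here.

Compound 3 `Cn1nc(Cc2nnc(SCCCCCCCC(=O)Nc3ccc(Cl)cc3Cl)n2CCC=O)c2ccccc2c1=O` carries a 2-formylethyl group on an aromatic nitrogen of the five-membered aromatic ring with three nitrogens in the shared core. In an assay on NK92 cells for inhibition of interleukin-2 (Homo sapiens), read by AlphaScreen, with stated times of 30 min and 1 h (a higher number here means a weaker inhibitor, a lower number a stronger inhibitor), compound 3 gives 960 nM, the higher of the two numbers recorded; the nearest is compound 1 `Cn1c(Cc2nn(C)c(=O)c3ccccc23)nnc1SCCCCCCCC(=O)Nc1ccc(Cl)cc1Cl`, which in this assay gives 350 nM. Compound 2 `CCOC(CCn1c(Cc2nn(C)c(=O)c3ccccc23)nnc1SCCCCCCCC(=O)Nc1ccc(Cl)cc1Cl)OCC` returned only a limit in this assay, > 30000 nM, sitting at the limit of > 30000 nM in this assay, at which 1 of the 3 values shown sits. The measured steps among these three run a 2.7-fold higher number from compound 1 to compound 3 (0.44 log units; beyond the scatter), an at least 85-fold higher number from compound 1 to compound 2 (1.93 log units; beyond the scatter) and an at least 31-fold lower number from compound 2 to compound 3 (1.49 log units; beyond the scatter).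

Compound 4 `Cn1nc(Cc2nnc(SCCCCCCCC(=O)Nc3ccc(Cl)cc3Cl)[nH]2)c2ccccc2c1=O` differs from compound 3 by hydrogen in place of 2-formylethyl on an aromatic nitrogen. Going by the values given here, no measured step strips this nitrogen to hydrogen, so the evidence bears only indirectly: a 2.7-fold higher number from compound 1 to compound 3 (0.44 log units; beyond the scatter) shows that extending the group on this nitrogen from methyl to 2-formylethyl costs a modest amount, and an at least 85-fold higher number from compound 1 to compound 2 (1.93 log units; beyond the scatter) that the diethoxyethyl chain costs far more. Removing the chain entirely is expected to undo the modest loss rather than add to it, placing compound 4 close to compound 1. The expected step is therefore a 1.9-fold lower number from compound 3 to compound 4 (0.28 log units; within the scatter), and the estimate for compound 4 in this assay is 500 nM, with a plausible range from 150 nM to 3000 nM.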

Compound 4, half-maximal inhibitory concentration: 450 nM
Compound 4: the middle estimate sits 1.1-fold (0.05 log units) above what was measured; the measured number falls inside the stated range.
By their numbers in this assay, from the lowest: compounds 1 and 4 (each within the scatter of the next); then compound 3. At a limit, above all of these: compound 2.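

In this assay, hydrogen and methyl on this aromatic nitrogen cannot be told apart, a 1.3-fold higher number from compound 1 to compound 4 (0.11 log units; within the scatter), so the methyl group of compound 1 adds nothing measurable to the number it gives. Compound 4 also gives the position a reference with nothing on this nitrogen, and against it the 2-formylethyl group has a real but limited cost, seen in reverse as a 2.1-fold lower number from compound 3 to compound 4 (0.33 log units; beyond the scatter). Against the same reference the 3,3-diethoxypropyl group has a far larger cost, an at least 66-fold lower number from compound 2 to compound 4 (1.82 log units; beyond the scatter), though this step rests on a limit for compound 2 and so gives only a bound on its size: the limit of > 30000 nM in this assay, at which 1 of the 4 values shown sits.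

Going by these compounds, what remains open is whether any group on this aromatic nitrogen can give a lower number than hydrogen and methyl do, and whether a chain ending in an amine or a carboxylic acid would stay close to compound 4 or fall as far as compound 2. The compounds shown also leave unresolved how much of the large loss belongs to the diethoxy end of the chain, and a simple propyl group would be needed to separate the chain from that end.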